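This account rests on a few compounds, and the source may have more. Where it says the series, first, only, none or still open, it means among the compounds named here.

Measured so far:
Compound 1 `C/C(=C\c1cc(-c2ccccc2)cs1)C(N)=O` in a functional assay on T-24 cells (Homo sapiens) for cytotoxicity, read by CCK-8 assay, with a stated time of 24 h (a lower number here means a stronger inhibitor, a higher number a weaker inhibitor), gives > 50000 nM, a limit of the assay.
Compound 2 `C/C(=C\c1nc(-c2ccccc2)cs1)C(N)=O` gives > 50000 nM, a limit of the assay.
Compound 3 `C/C(=C\c1nc(-c2ccc(C)cc2)cs1)C(N)=O` gives > 50000 nM, a limit of the assay.

Compound 3 therefore stands at the limit rather than at a number, and so do the other two values shown; the limit of > 50000 nM in this assay, at which 3 of the 3 values shown sit, is the whole record. Within the data shown here, the only one-place step, a step that the two limits leave unreadable from compound 2 to compound 3, is not readable because both ends are limits. The change from compound 3 to compound 4 `C/C(=C\c1nc(-c2ccc(F)cc2)cs1)C(N)=O` is fluoro in place of methyl on an aromatic carbon. Among the measured compounds shown here, no measured step bears on this change in a readable way, so no step beyond the scatter is expected; the estimate for the step is a step that the limit leaves unreadable from compound 3 to compound 4. Compound 4 is expected to give 60000 nM, ranging from 20000 nM to 200000 nM, most likely again reported only as a limit.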

Compound 4, half-maximal inhibitory concentration: > 50000 nM
Compound 4 was reported as a limit; the forecaster's own chance of this, stated with the estimate: 85%; the middle value does not contradict the limit.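

Compound 4 gives > 50000 nM, a limit of the assay. Among these compounds, no new step to compound 4 from compound 2 or compound 3 can be read. The compounds shown leave open whether any change to this series gives a measurable value in this assay: the limit of > 50000 nM in this assay, at which 4 of the 4 values shown sit.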